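Methoxy Added to Compound 2: Expected Antiproliferative Potency

The source may report more compounds than this note shows. Statements on the series, on what has been measured and on what is new or still open speak of the compounds shown alone.

Measured in a functional assay on HCT-116 cells (Homo sapiens) for antiproliferative activity, read by sulforhodamine B assay, with a stated time of 72 h; a higher number here means a weaker inhibitor, a lower number a stronger inhibitor:
Compound 1 `COc1ncc(-c2ccc3ncnc(Nc4cnn(CCCO)c4)c3c2)cc1NS(C)(=O)=O` gives 1420 nM.
Compound 2 `COc1ncc(-c2ccc3ncnc(Nc4ccc(OCCO)cc4)c3c2)cc1NS(=O)(=O)c1ccc(F)cc1F` gives 1060 nM.
Compound 3 `COc1ncc(-c2ccc3ncnc(Nc4cnn(CC(=O)O)c4)c3c2)cc1NS(=O)(=O)c1ccc(F)cc1F` gives 1540 nM.

Among these three numbers, compound 2 shows the lowest one, but it is not separated from the others by more than the usual scatter: compound 1 sits close to it, and the only single-point step recorded, a 1.5-fold higher number from compound 2 to compound 3 (0.16 log units; within the scatter), is also within the scatter. All three compounds share the same core and differ only in the group attached to the nitrogen on the aromatic ring.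

Compound 4 `COc1cc(Nc2ncnc3ccc(-c4cnc(OC)c(NS(=O)(=O)c5ccc(F)cc5F)c4)cc23)ccc1OCCO` is the next compound and has not yet been measured. It differs from compound 2 in one place: methoxy in place of hydrogen on an aromatic carbon. Within the data shown here, no measured step tests a methoxy at this position; the one step available, from compound 2 to compound 3, exchanges a different part of the molecule and was small. There is therefore nothing in the data to suggest a shift beyond the scatter, and the expectation is a step of about a 1.1-fold lower number from compound 2 to compound 4 (0.03 log units; within the scatter), meaning essentially no change.

Compound 4 is expected to give about 1000 nM in this assay, within a range from 450 nM to 2300 nM.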

Compound 4, half-maximal inhibitory concentration: 5720 nM
Estimate against measurement, compound 4: 5.7-fold (0.76 log units) below; measured number outside the range, above it.
By their numbers in this assay, from the lowest: compounds 2, 1 and 3 (each within the scatter of the next); then compound 4.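

Among these compounds, the 4-(2-hydroxyethoxy)phenyl group proves sensitive to a small addition in this assay: putting methoxy on its aromatic carbon, ortho to a 2-hydroxyethoxy group, gives a step beyond the scatter (a 5.4-fold higher number from compound 2 to compound 4 (0.73 log units; beyond the scatter)), whereas the one earlier step, (a 1.5-fold higher number from compound 2 to compound 3 (0.16 log units; within the scatter)), stayed within it. Exchanging the whole group on the nitrogen had therefore moved the number less than this single methoxy did, and 4-(2-hydroxyethoxy)-3-methoxyphenyl also stands apart from 1-(carboxymethyl)-1H-pyrazol-4-yl (a 3.7-fold higher number from compound 3 to compound 4 (0.57 log units; beyond the scatter)), so the aryl group is not as freely exchangeable as the first three compounds suggested. No measurement here offers an explanation for this shift.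

The compounds shown leave open whether the step belongs to methoxy in particular or would also appear with fluorine, a hydroxyl group, an amine or a longer chain such as ethoxy on the same carbon. They also leave open whether methoxy on this carbon would give a similar step with a different group on the sulfonamide, such as the methyl group of compound 1.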